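The compounds below may be only part of what the source reports. "The series", "measured", "known", "first", "only" and "open" are said of these compounds alone.

Measured compounds in an ADME assay on Vero cells (Chlorocebus sabaeus) for cytotoxicity, with a stated time of 7 days; on this read-out higher numbers stand for lower toxicity in this test and lower numbers for higher toxicity in this test:

Compound 1 `COc1ccc2[nH]c(C(=O)N3CC(=O)N(Cc4ccccc4)[C@@H](COCc4ccccc4)C3)cc2c1` reports a limit, not a number: > 30000 nM.
Compound 2 `COc1ccc2[nH]c(C(=O)N3CC(=O)N(Cc4cccc(OC)n4)[C@@H](Cc4ccccc4)C3)cc2c1` reports a limit, not a number: > 30000 nM.
Compound 3 `COc1ccc2[nH]c(C(=O)N3CC(=O)N(Cc4ccccc4)[C@@H](N4CCc5ccccc54)C3)cc2c1` reports a limit, not a number: > 100000 nM.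

All three compounds share the same core and differ only in the groups carried on the six-membered non-aromatic ring. In this assay none of them gave a readable number. Compound 3 sits at the higher of the two limits, which is the limit of > 100000 nM in this assay, at which 1 of the 3 values shown sits. Compound 1 and compound 2 sit at the limit of > 30000 nM in this assay, at which 2 of the 3 values shown sit. For the measured compounds named here, the only single-point step among the measured compounds, a step that the two limits leave unreadable from compound 1 to compound 3, therefore cannot be read, since both ends are limits.

Compound 4 `COc1ccc2[nH]c(C(=O)N3CC(=O)N(Cc4ccccc4)[C@@H](CN4CCn5cccc5C4)C3)cc2c1` is the compound not yet measured. Its difference from compound 3 is a group of 10 heavy atoms (8 carbon, 2 nitrogen; one five-membered aromatic ring with 1 hetero atom, one six-membered non-aromatic ring with 2 hetero atoms) in place of a group of 9 heavy atoms (8 carbon, 1 nitrogen; one five-membered non-aromatic ring with 1 hetero atom, one six-membered aromatic ring of carbon only), on a saturated ring carbon.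

Going by the values given here, no measured step gives a readable size for a change at this position, so there is no basis to expect a move beyond the scatter in this assay. The most likely outcome is that compound 4 again reaches a limit rather than a number. Compound 4 is expected to give 100000 nM, within 30000 nM to 300000 nM. The step of a number no higher from compound 3 to compound 4 (the limit leaves the size open) is thus expected to be no more than the scatter, with a limit the probable report.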

Compound 4, half-maximal cytotoxic concentration: > 100000 nM
Compound 4 ended at the assay's limit; the forecaster's own chance of this, stated with the estimate: 85%; the middle value lies on the limit itself.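

In this assay compound 4 gives > 100000 nM, which is a limit and not a number. Neither the step from compound 3 to compound 4 nor the step from compound 1 to compound 4 can be read: both ends of each are limits. The compounds shown leave open at what concentration any of them becomes toxic to these cells, and whether the groups changed on the shared core make any difference.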